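Thienylmethylamine series: compound 4

A few compounds are considered here, and "the series" means these few. Any claim that something is new, unique, unknown or untested is made for them only; others in the source may bear on it.

Measured so far in a functional assay on CHO cells for agonist activity at adenosine receptor A2b (Homo sapiens), read by scintillation counting and cAMP accumulation, with a stated time of 150 min, in the presence of a further agent that is not named here; a lower number here means a stronger inhibitor, a higher number a weaker inhibitor:
compound 1 `Cc1ccc(-c2nc3c(N)nc(NCc4cccs4)nc3s2)o1`: 91 nM
compound 2 `COc1cccc(CNc2nc(N)c3nc(-c4cccs4)sc3n2)c1`: 2770 nM
compound 3 `COc1ccccc1CNc1nc(N)c2nc(-c3cccs3)sc2n1`: 4570 nM

Compound 3 gives the highest number of the three; the step of a 1.6-fold higher number from compound 2 to compound 3 (0.22 log units; within the scatter) is within the scatter, so compound 2 and compound 3 are not separated, while compound 1 sits far lower. Compound 4 `Nc1nc(NCc2cccs2)nc2sc(-c3cccs3)nc12` differs from compound 3 by thiophen-2-yl in place of 2-methoxyphenyl on a saturated chain carbon bound to a nitrogen on an aromatic ring. Going by the values given here, no measured step covers this exchange: the only step in the set swaps one methoxyphenyl for the other and stays within the scatter. Compound 1 carries the same thiophen-2-yl on the chain carbon and gives 91 nM, but it also differs from compound 4 elsewhere, so its number is only a pointer. A step of a 13-fold lower number from compound 3 to compound 4 (1.12 log units; beyond the scatter) toward lower numbers is expected for compound 4. Compound 4 is estimated at 350 nM, with a range from 80 nM to 1600 nM in this assay.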

Compound 4, half-maximal inhibitory concentration: 547 nM
The estimate for compound 4 lay 1.6-fold (0.19 log units) below the measured number; the measured number falls inside the stated range.
By their numbers in this assay, from the lowest: compound 1; then compound 4; then compounds 2 and 3 (each within the scatter of the next).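

On the saturated chain carbon bound to a nitrogen on an aromatic ring, the two methoxyphenyl groups were not separated in this assay, but thiophen-2-yl in place of 2-methoxyphenyl gives an 8.4-fold lower number from compound 3 to compound 4 (0.92 log units; beyond the scatter) and in place of 3-methoxyphenyl gives a 5.1-fold lower number from compound 2 to compound 4 (0.70 log units; beyond the scatter), so the group at this position does change the number. With thiophen-2-yl on that chain carbon, thiophen-2-yl in place of 5-methylfuran-2-yl on an aromatic carbon gives a 6.0-fold higher number from compound 1 to compound 4 (0.78 log units; beyond the scatter), so this second position also changes the number. No measurement offered here explains either change.

Going by these compounds, whether unsubstituted phenyl on the chain carbon would fall with the methoxyphenyl compounds or nearer compound 4 remains open. Also open, on these data alone, is whether 5-methylfuran-2-yl on the aromatic carbon would give the same lower number with a methoxyphenyl on the chain.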